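A few compounds are considered here, and "the series" means these few. Any claim that something is new, unique, unknown or untested is made for them only; others in the source may bear on it.

Of the compounds shown here, three have been read in a toxicity assay on THP-1 cells (Homo sapiens) for inhibition (a higher number here means that more compound is tolerated, a lower number that less compound is tolerated), and none of them gives a number. Compound 1 `Cc1cccc(C(=O)Nc2ncc(-c3ccccc3)n2C)c1` gives > 50000 nM, which is a limit of the assay. Compound 2 `CCCn1c(-c2ccc(OC)cc2)cnc1NC(=O)c1ccc(F)cc1` gives > 100000 nM, which is also a limit. Compound 3 `COc1ccc(-c2cnc(NC(=O)C3CCCCC3)n2C)cc1` gives > 100000 nM, again a limit. Compound 2 therefore stands at the limit of > 100000 nM in this assay, at which 2 of the 3 values shown sit, while the remaining value sits at the limit of > 50000 nM in this assay, at which 1 of the 3 values shown sits.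

Compound 4 `COc1ccc(-c2cnc(NC(=O)c3ccc(F)cc3)n2C(C)C)cc1` has the same atoms as compound 2, joined differently: isopropyl in place of propyl on an aromatic nitrogen. The change places isopropyl in place of propyl on an aromatic nitrogen, next to the ring atom that bears a 4-methoxyphenyl group. For the measured compounds named here, no two measured compounds differ in only one place, so the series gives no direct measure of such a step. The expected result is a number no higher from compound 2 to compound 4 (the limit leaves the size open), meaning no change beyond the scatter in either direction in this assay. Compound 4 is estimated at 100000 nM, with an expected range of 50000 nM to 200000 nM, and a report as a limit alone is likely.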

Compound 4, half-maximal cytotoxic concentration: > 50000 nM
Compound 4 ended at the assay's limit; the forecaster's own chance of this, stated with the estimate: 90%; the middle value lies beyond the limit too.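

Compound 2 and compound 4 both end at limits in this assay, so isopropyl in place of propyl on an aromatic nitrogen gives no readable step. The compounds shown leave open at what concentration any of them reaches the half-maximal cytotoxic read-out.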